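This account rests on a few compounds, and the source may have more. Where it says the series, first, only, none or still open, it means among the compounds named here.

Measured compounds:
compound 1 `Nc1cccc(-c2cn3nc(-c4cccs4)sc3n2)c1` — > 250000 nM
compound 2 `COc1ccc(-c2csc3nc(-c4cccc(N)c4)cn23)cc1` — 11000 nM
compound 3 `C=C(Br)C(=O)Nc1cccc(-c2cn3nc(CCc4ccccc4)sc3n2)c1` — 2600 nM

All three were run in a functional assay on FM3A cells (Mus musculus) for inhibition, read by cell counting, with a stated time of 2 days; on this read-out lower numbers stand for stronger inhibition and higher numbers for weaker inhibition. Compound 1 stands at the limit of > 250000 nM in this assay, at which 1 of the 3 values shown sits; for compound 1 there is no number, only this limit. Going by the values given here, compound 2 and compound 3 are the two members with a numbered value, and both differ from compound 1 in more than one place, so no single step between measured compounds can be read from the set. Where compound 1 stands relative to the others is therefore only this: it sits at the limit, while compound 2 and compound 3 do not.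

Compound 4 `Nc1cccc(-c2cn3nc(-c4ccccc4)sc3n2)c1` is the unmeasured member. It arises from compound 1 by phenyl in place of thiophen-2-yl on an aromatic carbon. Among the compounds with values here, no measured step of this kind is available, and nothing in the set shows that swapping one aromatic ring for another at this position moves the read-out. The step from compound 1 to compound 4 is expected to be small, an at least 1.2-fold lower number from compound 1 to compound 4 (0.09 log units; that floor lies within the scatter), none beyond the usual scatter. Compound 4 is accordingly estimated at 200000 nM, within 30000 nM to 600000 nM, and it is expected that the assay may again report only a limit rather than a number.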

Compound 4, half-maximal inhibitory concentration: 14000 nM
The estimate for compound 4 lay 14-fold (1.15 log units) above the measured number; measured number outside the range, below it.
By their numbers in this assay, from the lowest: compound 3; then compounds 2 and 4 (each within the scatter of the next). At a limit, above all of these: compound 1.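

Working notes on the aromatic carbon of the five-membered ring, next to the ring nitrogen and next to the ring sulfur: this position is not indifferent to the ring it carries, a point the earlier compounds could not show, as none of them differed from another in one place only. In this assay, phenyl in place of thiophen-2-yl gives an at least 17-fold lower number from compound 1 to compound 4 (1.25 log units; beyond the scatter), so the exchange of one aromatic ring for another is enough to move the read-out beyond the scatter. Its full size stays unknown because compound 1 has no number, only a limit: the limit of > 250000 nM in this assay, at which 1 of the 4 values shown sits.

From the compounds shown here alone, whether this step reflects something particular to phenyl or to the loss of thiophen-2-yl stays open, since a single pair cannot separate the two, and a pyridine ring, a cyclohexyl group or a phenyl ring carrying a methoxy group at this carbon would be needed to tell them apart. Also open, going by these compounds, is whether the same exchange has a similar effect when the free amine of the shared core is replaced by an amide, or when a longer chain stands at this carbon.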